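A few compounds are considered here, and "the series" means these few. Any claim that something is new, unique, unknown or untested is made for them only; others in the source may bear on it.

Three compounds sharing one core were tested in a functional assay on PC-3 cells (Homo sapiens) for cytotoxicity, read by MTT assay, with a stated time of 72 h, tested at 1 uM; a lower number here means a stronger effect, a higher number a weaker effect of the compound at the concentration tested. Compound 1 `COC(=O)Nc1nc2cc(Oc3cccc(N4CCN(C)CC4)n3)ccc2[nH]1` gives 98.1% in this assay. Compound 2 `COC(=O)Nc1nc2cc(Oc3cccc(N4CCN(C)CC4)c3)ccc2[nH]1` gives 73.1% in this assay. Compound 3 `O=C(Nc1nc2cc(Sc3ccccc3)ccc2[nH]1)OC1COC1` gives 107% in this assay, the highest of the three numbers; compound 1 lies within the scatter of it, so those two cannot be told apart, while compound 2 lies beyond the scatter, with the lower number. No two of these compounds differ in only one place, so no single-change step can be read from them.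

Compound 4 `O=C(Nc1nc2cc(C(=O)c3ccccc3)ccc2[nH]1)OC1COC1` has not yet been measured in this assay. It differs from compound 3 by benzoyl in place of phenylsulfanyl on an aromatic carbon. For the measured compounds named here, no measured pair shows what such an exchange does here, and both groups carry one six-membered aromatic ring of carbon only and one hydrogen-bond acceptor. The step from compound 3 to compound 4 is therefore expected to be a number 9 percentage points lower from compound 3 to compound 4 (within the scatter), not beyond the scatter. Compound 4 is estimated to give 98% in this assay, with a range from 80% to 112%.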

Compound 4, a percentage reported as activity, at one concentration (the size of the read-out at that concentration, not a potency): 90.9%
The estimate for compound 4 lay 7.1 percentage points above the measured number; measured number inside the range.
By their numbers in this assay, from the lowest: compound 2; then compounds 4, 1 and 3 (each within the scatter of the next, the first and the last beyond it).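

For the compounds shown here, compound 3 and compound 4 give the first single-change comparison in this set. In this assay, benzoyl in place of phenylsulfanyl on an aromatic carbon gives a number 16.1 percentage points lower from compound 3 to compound 4 (beyond the scatter). This shows that the group at this carbon, meta to a fused ring and para to a fused ring, can shift the read-out even though both groups carry one six-membered aromatic ring of carbon only and one hydrogen-bond acceptor. Nothing available here explains why the exchange has this effect.

This single step cannot show whether an anilino or a phenylsulfonyl group at the same carbon would lower the number further or raise it. It also leaves open whether benzoyl would give a similar step on the methyl carbamate found in compound 1 and compound 2.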